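The source may hold more compounds than are shown below. What is called first, only, known or untested is meant among the compounds shown, and "the series" means these compounds.

Three compounds have so far been examined in a functional assay on K562 cells (Homo sapiens) for cytotoxicity, read by MTT assay; on this read-out lower numbers stand for higher toxicity in this test and higher numbers for lower toxicity in this test. Compound 2, with the structure `COC(=O)C(C)(O)[C@](O)(C[C@H](C)CC/C=C(/C)CC/C=C(/C)CCCC1=CCN(CC(=O)O)C1=O)C(=O)OC`, reaches only a limit of the assay in this test, > 100 ug/mL. Compound 1, `CC1=C(O)/C(=C/[C@H](C)CCC/C(C)=C/CC/C(C)=C/CCC2=CC(O)OC2=O)OC1=O`, likewise stops at a limit, > 100 ug/mL. Compound 3, `CC1=C(O)/C(=C/[C@H](C)CCC/C(C)=C/CCC(C)(O)CCCc2ccoc2)OC1=O`, also gives no more than a limit, > 100 ug/mL. Compound 2 therefore stands where every value shown stands, namely at the limit of > 100 ug/mL in this assay, at which 3 of the 3 values shown sit. Going by the values given here, since no two measured compounds differ in just one place, no measured step is available to learn from.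

Compound 4, `COC(=O)C(C)(O)[C@](O)(C[C@H](C)CC/C=C(/C)CC/C=C(/C)CCCc1ccoc1)C(=O)OC`, is the next one to be tested. It differs from compound 2 in one place: a group of 5 heavy atoms (4 carbon, 1 oxygen; one five-membered aromatic ring with 1 hetero atom) in place of a group of 10 heavy atoms (6 carbon, 1 nitrogen, 3 oxygen; one five-membered non-aromatic ring with 1 hetero atom), on a saturated chain carbon, three bonds along the chain from a double-bonded chain carbon. Among the compounds with values here, no measured step covers a change of this kind, so the expectation for compound 4 rests on compound 2 sitting at the limit of > 100 ug/mL in this assay, at which 3 of the 3 values shown sit. The expected step is a step that the limit leaves unreadable from compound 2 to compound 4, none beyond the scatter. Compound 4 is thus estimated to give 150 ug/mL, with a range from 100 ug/mL to 300 ug/mL, most probably again as a limit only.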

Compound 4, concentration lethal to 50% of the cells: 34 ug/mL
Beside the measured number, compound 4's estimate is 4.4-fold (0.64 log units) above it; the measured number lies below the stated range.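

Until this point, no single change could be read in this assay, so nothing showed that this end of the chain had any bearing on the result. Putting furan-3-yl in place of the larger five-membered non-aromatic ring group, on the saturated chain carbon, gives an at least 2.9-fold lower number from compound 2 to compound 4 (0.46 log units; beyond the scatter), which means higher toxicity in this test, and this size is only a minimum, as the starting value is a limit and not a number. Compound 1, compound 2 and compound 3 all stop at a limit: the limit of > 100 ug/mL in this assay, at which 3 of the 4 values shown sit.

On these data alone, what stays open is whether the furan ring itself matters, or whether it is enough to lose the larger group. A phenyl ring, a thiophene or a plain methyl group at this place would help to separate those two readings.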